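From an Aminophenyl to a Difluorophenyl: Cytotoxicity Expected Unchanged

A few compounds are considered here, and "the series" means these few. Any claim that something is new, unique, unknown or untested is made for them only; others in the source may bear on it.

Compound 1, `CCOC(=O)c1cc(-c2cccc(OCc3cccc(N)c3)c2)on1`, was examined in an ADME assay on Vero cells (Chlorocebus sabaeus) for cytotoxicity, with a stated time of 72 h; a higher number here means a weaker inhibitor, a lower number a stronger inhibitor. In this assay compound 1 gives > 128000 nM, which is a limit of the assay rather than a measured number. Two related compounds were examined in the same way. Compound 2, `CCOC(=O)c1ccc(COc2cccc(-c3cc(C(=O)OCC)no3)c2)cc1`, gives > 128000 nM in this assay, again a limit. Compound 3, `CCOC(=O)c1cc(-c2cccc(OCc3cccc(C(F)(F)F)c3F)c2)on1`, gives > 128000 nM in this assay, also a limit. Compound 1 therefore stands where every measured compound stands: the limit of > 128000 nM in this assay, at which 3 of the 3 values shown sit. Among the measured compounds shown here, no two measured compounds differ in only one place, so no measured step between them can be described.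

Compound 4, `CCOC(=O)c1cc(-c2cccc(OCc3cc(F)ccc3F)c2)on1`, has not yet been measured. It differs from compound 1 in a single place: 2,5-difluorophenyl in place of 3-aminophenyl on a saturated chain carbon bound to an oxygen on an aromatic ring. The change removes the amine-bearing ring and puts a fluorinated ring in its place, while the shared core and the ester on it stay as they are.

The step that the limit leaves unreadable from compound 1 to compound 4 is expected to be none beyond the scatter, an expectation that rests on (the limit of > 128000 nM in this assay, at which 3 of the 3 values shown sit). For compound 4 the estimate is 150000 nM, within a range from 100000 nM to 300000 nM, and the assay is expected most likely to report only a limit again.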

Compound 4, half-maximal inhibitory concentration: > 128000 nM
Compound 4: no number, only a limit; the forecaster's own chance of this, stated with the estimate: 85%; the middle value does not contradict the limit.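

In this assay compound 4 gives > 128000 nM, which is a limit of the assay and not a number. Among the compounds shown here, compound 1 also stands at a limit, so no step from compound 1 to compound 4 can be read. The compounds shown leave open what actual half-maximal value, if any, each of them has in these cells.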